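Cytotoxicity notes on alkynyl analogues of a shared core

The source may hold more compounds than are shown below. What is called first, only, known or untested is meant among the compounds shown, and "the series" means these compounds.

Measured so far:
- compound 1, `CCCCCCCC#Cc1cc2cn(COCCO)c(=O)nc2o1`: 200000 nM
- compound 2, `OCCOCn1cc2ccnc-2nc1O`: > 400000 nM

In a functional assay on HEL cells (Homo sapiens), read by microscopy (a lower number here means that less compound is tolerated, a higher number that more compound is tolerated), compound 1 gives 200000 nM. For compound 2 the value is a limit of the assay and not a number. Among the two values shown, that of compound 1 is therefore the only number; the other value sits at the limit of > 400000 nM in this assay, at which 1 of the 2 values shown sits.

Compound 3, `CCCCCCCCCC#Cc1cc2cn(COCCO)c(=O)nc2o1`, is not yet measured in this assay. It differs from compound 1 by ethyl in place of hydrogen on a saturated chain carbon, seven bonds along the chain from a triple-bonded carbon. The shared core of compound 1 and compound 3 is kept; only the saturated chain beyond the triple-bonded carbon is extended.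

No step between measured compounds is available, so the size of the step to compound 3 cannot be read from the data shown. The expected step in this assay from compound 1 to compound 3 is a 2.0-fold lower number from compound 1 to compound 3 (0.30 log units; within the scatter), a modest lowering of the tolerated concentration, with the range wide enough to include no change beyond the scatter. Compound 3 is expected to give 100000 nM, estimated between 40000 nM and 250000 nM.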

Compound 3, minimum cytotoxic concentration: >= 20000 nM
Compound 3 was reported as a limit; the forecaster's own chance of this, stated with the estimate: 10%; the middle value does not contradict the limit.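

In this assay, for the compounds shown here, compound 3 stands at the limit >= 20000 nM and not at a number, so no step from compound 1 to compound 3 can be read. The compounds shown leave open whether extending the saturated chain beyond the triple-bonded carbon changes the tolerated concentration at all, and by how much.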